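Allyloxy to hydroxy: the step to compound 3

The source may hold more compounds than are shown below. What is called first, only, known or untested is meant among the compounds shown, and "the series" means these compounds.

Among the compounds with values here, only two numbers are available so far. Compound 1 (`O=C(c1cccnc1)c1cc(F)ccc1O`) gives 6210 nM in a functional assay on IMR-32 cells (Homo sapiens) for cytotoxicity, read by sulforhodamine B assay, with a stated time of 48 h (a lower number here means a stronger inhibitor, a higher number a weaker inhibitor), and serves as the reference point for this step. Compound 2 (`C=CCOc1ccc(C)cc1C(=O)c1cccnc1`) gives 87000 nM in this assay and holds the higher of the two numbers, which makes it the weaker inhibitor of the pair by a gap beyond the usual scatter.

Compound 3 (`Cc1ccc(O)c(C(=O)c2cccnc2)c1`) follows from compound 2 by hydrogen in place of allyl on an oxygen on an aromatic ring with hydrogen in place of allyl on an oxygen on an aromatic ring, or allyloxy to hydroxy. Within the data shown here, no measured pair isolates this change, so the expectation is thinly supported. It rests on compound 1 alone, which also carries a hydroxy group and gives 6210 nM in the same read-out.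

A large fall in the number, beyond the scatter, is therefore expected, with an 11-fold lower number from compound 2 to compound 3 (1.04 log units; beyond the scatter) as the estimated step. Compound 3 is estimated at 8000 nM with an expected range from 2500 nM to 25000 nM for a single measurement.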

Compound 3, half-maximal inhibitory concentration: 5540 nM
The estimate for compound 3 lay 1.4-fold (0.16 log units) above the measured number, within the range that was stated.
By their numbers in this assay, from the lowest: compounds 3 and 1 (each within the scatter of the next); then compound 2.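

In this assay, within the data shown here, hydrogen in place of allyl on an oxygen on an aromatic ring gives a 16-fold lower number from compound 2 to compound 3 (1.20 log units; beyond the scatter), the first measured pair that isolates allyloxy to hydroxy. In this pair, the large step goes with the hydroxy compound having the lower number, although a single pair sets no general pattern for the series. Methyl in place of fluoro on an aromatic carbon gives a 1.1-fold lower number from compound 1 to compound 3 (0.05 log units; within the scatter), so compound 1 and compound 3 cannot be told apart in this read-out, and with the hydroxy present these two groups read alike at that place. No accompanying measurement bears on what lies behind either step, and the numbers record only the size of each one.

On these data alone, whether the higher number of compound 2 belongs to the allyl group specifically or would also appear with any other group on that oxygen remains open, and a methyl ether, a longer saturated chain such as propyl, or an acetyl ester would separate these cases. As far as these compounds go, it is also open whether methyl and fluoro still read alike when allyloxy replaces the hydroxy, and how a chloro group or an amine would read on that aromatic carbon.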